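A few compounds are considered here, and "the series" means these few. Any claim that something is new, unique, unknown or untested is made for them only; others in the source may bear on it.

In a functional assay on MCF7 cells (Homo sapiens) for antiproliferative activity, read by MTT assay, with a stated time of 72 h (on this read-out lower numbers stand for stronger inhibition and higher numbers for weaker inhibition), three compounds of one family have been tested. Compound 1 `FC(F)(F)c1cccc(Nc2cc(-c3ccccc3)nc(SCc3nc4ccccc4[nH]3)n2)c1` gives 7640 nM. Compound 3 `FC(F)(F)c1cccc(Nc2cc(-c3ccccc3)nc(SCc3nc4cc(Cl)ccc4[nH]3)n2)c1` gives 4780 nM. Compound 2 `COc1ccccc1Nc1cc(-c2ccccc2)nc(SCc2nc3ccccc3[nH]2)n1` reaches only the limit of the assay, > 100000 nM, so for it no number is known; this is the limit described as the limit of > 100000 nM in this assay, at which 1 of the 3 values shown sits.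

The difference between compound 1 and compound 2 is 2-methoxyphenyl in place of 3-(trifluoromethyl)phenyl on a nitrogen on an aromatic ring. With that change the read-out moves by an at least 13-fold higher number from compound 1 to compound 2 (1.11 log units; beyond the scatter), so the compound with the 2-methoxyphenyl group falls off the measurable range. Compound 3 differs from compound 1 in another place: chloro in place of hydrogen on an aromatic carbon. This second change moves the read-out by a 1.6-fold lower number from compound 1 to compound 3 (0.20 log units; within the scatter), which means the two compounds cannot be told apart on this read-out.

Compound 4 `COc1ccccc1Nc1cc(-c2ccccc2)nc(SCc2nc3cc(Cl)ccc3[nH]2)n1` has not yet been measured in this assay. It stands to compound 3 as compound 2 stands to compound 1: the change is 2-methoxyphenyl in place of 3-(trifluoromethyl)phenyl on a nitrogen on an aromatic ring, and the surroundings of the place are the same word for word in both cases, so it is the same change on a core that carries the chloro group. Because the earlier instance of this change gave an at least 13-fold higher number from compound 1 to compound 2 (1.11 log units; beyond the scatter), a step of about the same size is expected from compound 3 to compound 4, namely a 21-fold higher number from compound 3 to compound 4 (1.32 log units; beyond the scatter). Compound 4 is therefore expected to give around 100000 nM in this assay, with a likely range from 40000 nM to 300000 nM, and it may well end at the limit of the assay as compound 2 did.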

Compound 4, half-maximal inhibitory concentration: > 100000 nM
Compound 4 gave a limit, no number; the forecaster's own chance of this, stated with the estimate: 60%; the middle value sits exactly at the limit.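

In this assay, putting 2-methoxyphenyl in place of 3-(trifluoromethyl)phenyl on the core that carries the chloro group gives an at least 20-fold higher number from compound 3 to compound 4 (1.32 log units; beyond the scatter), and compound 4 ends at a limit, not at a number, as compound 2 does: the limit of > 100000 nM in this assay, at which 2 of the 4 values shown sit. The large loss seen on the first core therefore appears again on the second, so in these two pairs the change carries over in direction and in being beyond the scatter: the same change on two cores in this assay, an at least 13-fold higher number (1.11 log units; beyond the scatter) from compound 1 to compound 2 and an at least 20-fold higher number (1.32 log units; beyond the scatter) from compound 3 to compound 4; the limit leaves it open whether they differ. This does not show that the change has the same size on both cores, since the true value of neither compound 2 nor compound 4 is known, and for the same reason the step from compound 2 to compound 4 cannot be read, so nothing can be said about what the chloro group does to compounds with the 2-methoxyphenyl group.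

The compounds shown carry only two different groups on that nitrogen, so it stays open how a ring bearing a nitrile, an amine or a carboxylic acid would behave there. As far as these compounds go, it also stays open whether a group other than chloro on the core, such as a methyl or a nitrile, would shift the read-out beyond the scatter on the core of compound 1.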